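Lengthening the Chain of a Hydroxamate Growth Inhibitor

The source may hold more compounds than are shown below. What is called first, only, known or untested is meant among the compounds shown, and "the series" means these compounds.

Compound 1, `C#CCN(C)Cc1cccc(NC(=O)CCCC(=O)NO)c1`, gives in a functional assay on PC-3 cells (Homo sapiens) for inhibition, read by MTT assay, with a stated time of 48 h (on this read-out higher numbers stand for weaker inhibition of growth and lower numbers for stronger inhibition of growth), only a limit, > 10000 nM. Compound 2, `C#CCN(C)Cc1ccc(NC(=O)CCCCC(=O)NO)cc1`, likewise gives only a limit, > 10000 nM. Compound 2 therefore stands at the limit of > 10000 nM in this assay, at which 2 of the 2 values shown sit, with no number of its own to compare. Compound 3, `C#CCN(C)Cc1ccc(NC(=O)CCCCCCC(=O)NO)cc1`, has not yet been measured; it differs from compound 2 by 2-(hydroxycarbamoyl)ethyl in place of hydroxycarbamoyl on a saturated chain carbon, four bonds along the chain from a carbonyl carbon. Going by the values given here, no measured step shows how this change acts, so the expectation rests on the limits alone. The longer chain is expected to shift compound 3 toward stronger inhibition, an estimated step of an at least 2.0-fold lower number from compound 2 to compound 3 (0.30 log units; that floor lies within the scatter). Compound 3 is expected near 5000 nM, between 1500 nM and 20000 nM.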

Compound 3, concentration for 50% growth inhibition: 2280 nM
Estimate against measurement, compound 3: 2.2-fold (0.34 log units) above; the range from low to high includes it.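

In this assay, 2-(hydroxycarbamoyl)ethyl in place of hydroxycarbamoyl at this saturated chain carbon gives an at least 4.3-fold lower number from compound 2 to compound 3 (0.64 log units; beyond the scatter). Going by these compounds alone, this lengthening of the chain therefore yields the first value here that is a number rather than a limit, and the step lies beyond the usual scatter. Its full size remains unknown, since compound 2 gives only a limit: the limit of > 10000 nM in this assay, at which 2 of the 3 values shown sit.

Still open, going by these compounds, is whether a longer chain would lower the number further or lose the gain. Also open, on these data alone, is whether a carboxylic acid in place of hydroxycarbamoyl would retain any growth inhibition.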